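Trifluoromethoxy for trifluoromethyl in the triaryl series

The source may hold more compounds than are shown below. What is called first, only, known or untested is meant among the compounds shown, and "the series" means these compounds.

Compound 3 `Oc1cccc(-c2cc(-c3cccc(C(F)(F)F)c3)cc(-c3cccc(O)c3)n2)c1` gives 12700 nM in a functional assay on HeLa cells (Homo sapiens) for inhibition (a higher number here means a weaker inhibitor, a lower number a stronger inhibitor), the highest of the three numbers: compound 1 `Oc1cccc(-c2cc(-c3cccc(F)c3)cc(-c3cccc(O)c3)n2)c1` gives 1400 nM and compound 2 `Oc1cccc(-c2cc(-c3ccc(F)cc3)cc(-c3cccc(O)c3)n2)c1` gives 1280 nM, so that a 9.1-fold higher number from compound 1 to compound 3 (0.96 log units; beyond the scatter) and a 9.9-fold higher number from compound 2 to compound 3 (1.00 log units; beyond the scatter), while a 1.1-fold lower number from compound 1 to compound 2 (0.04 log units; within the scatter). Compound 4 `Oc1cccc(-c2cc(-c3cccc(OC(F)(F)F)c3)cc(-c3cccc(O)c3)n2)c1` differs from compound 3 by trifluoromethoxy in place of trifluoromethyl on an aromatic carbon. Among the measured compounds shown here, no measured step exchanges trifluoromethyl for trifluoromethoxy; the only steps that touch this group, from fluoro to trifluoromethyl, were modest and beyond the scatter, but they do not show which way a further change at the same group goes. Compound 4 is therefore expected to show a 1.2-fold lower number from compound 3 to compound 4 (0.06 log units; within the scatter), a step within the scatter. Compound 4 is estimated at 11000 nM, with a range from 4000 nM to 35000 nM.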

Compound 4, half-maximal inhibitory concentration: > 50000 nM
Compound 4 ended at the assay's limit (the forecaster's own chance of this, stated with the estimate: 10%); middle value at least 4.5-fold (0.65 log units) from the limit.
By their numbers in this assay, from the lowest: compounds 2 and 1 (each within the scatter of the next); then compound 3. At a limit, above all of these: compound 4.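

Trifluoromethoxy in place of trifluoromethyl is not a neutral exchange at this position: the series shows an at least 3.9-fold higher number from compound 3 to compound 4 (0.59 log units; beyond the scatter). Measured from the fluoro compound, the change gives an at least 35-fold higher number from compound 1 to compound 4 (1.55 log units; beyond the scatter), so the loss seen with trifluoromethyl continues with trifluoromethoxy. The value of compound 4 in this assay is a limit, not a number: the limit of > 50000 nM in this assay, at which 1 of the 4 values shown sits.

From the compounds shown here alone, whether a methyl, a methoxy or an amine at this place returns to the level of compound 1 and compound 2 stays open. Also open, going by these compounds, is how far the loss with trifluoromethoxy actually extends.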